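Alkyl variation on the amine nitrogen of an adenosine-derived scaffold

This account rests on a few compounds, and the source may have more. Where it says the series, first, only, none or still open, it means among the compounds named here.

Measured compounds:
compound 2, `CC(C)N(CC[C@H](N)C(=O)O)C[C@H]1O[C@@H](n2cnc3c(N)ncnc32)[C@H](O)[C@@H]1O`, 44%
compound 3, `C=CCN(CC[C@H](N)C(=O)O)C[C@H]1O[C@@H](n2cnc3c(N)ncnc32)[C@H](O)[C@@H]1O`, 53.9%

Compound 1, `CCCN(CC[C@H](N)C(=O)O)C[C@H]1O[C@@H](n2cnc3c(N)ncnc32)[C@H](O)[C@@H]1O`, carries a propyl group on the amine nitrogen; in an assay for inhibition of tRNA (cytosine(38)-C(5))-methyltransferase (Homo sapiens), with a stated time of 5 min, tested at 100 uM (a lower number here means less inhibition, a higher number more inhibition at the concentration tested (going by the name of the read-out)), compound 1 shows no result reported. Compound 2 gives 44% in this assay, and compound 3 gives 53.9%. Among the compounds with values here, the only step between measured compounds, a number 9.9 percentage points higher from compound 2 to compound 3 (within the scatter), lies within the scatter, so swapping one small alkyl for another on this nitrogen has so far left the read-out unchanged. Compound 4, `C#CC(C)(C)N(CC[C@H](N)C(=O)O)C[C@H]1O[C@@H](n2cnc3c(N)ncnc32)[C@H](O)[C@@H]1O`, differs from compound 1 in that (1,1-dimethylprop-2-yn-1-yl in place of propyl on an amine nitrogen). Within the data shown here, no measured step covers this exact change, so the expectation rests on the flat behaviour seen across compound 2 and compound 3. Compound 4 is therefore expected to give about 48%, with a range of 30% to 66%.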

Compound 4, a percentage reported as inhibition, at one concentration (the size of the read-out at that concentration, not a potency): 17.3%
The estimate for compound 4 lay 30.7 percentage points above the measured number, outside the stated range (below it).
By their numbers in this assay, from the lowest: compound 4; then compounds 2 and 3 (each within the scatter of the next).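

In this assay this nitrogen no longer looks indifferent to its substituent: 1,1-dimethylprop-2-yn-1-yl in place of allyl gave a number 36.6 percentage points lower from compound 3 to compound 4 (beyond the scatter) and the read-out fell further than the small alkyl swap had moved it. Ethynyl in place of hydrogen on the saturated chain carbon bound to the amine nitrogen gave a number 26.7 percentage points lower from compound 2 to compound 4 (beyond the scatter) as well, so this single addition already goes with a lower number. Nothing at hand accounts for the drop.

As far as these compounds go, how a tert-butyl or a cyclopropyl group would read on this nitrogen remains open.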